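Three measured chalcone-bearing phenols and a fourth to estimate

A few compounds are considered here, and "the series" means these few. Any claim that something is new, unique, unknown or untested is made for them only; others in the source may bear on it.

Measured so far, in a functional assay on MCF7 cells (Homo sapiens) for cytotoxicity, read by MTT assay, with a stated time of 24 h; a lower number here means a stronger inhibitor, a higher number a weaker inhibitor:
Compound 1, `Cc1cc(O)c(C(=O)/C=C/c2ccccc2)c(-c2ccccc2)c1C(=O)/C=C/c1ccccc1`, gives 10000 nM.
Compound 2, `Cc1cc(O)c(C(=O)/C=C/c2ccccc2)c(-c2ccc(Br)cc2)c1C(=O)/C=C/c1ccccc1`, gives 10000 nM.
Compound 3, `Cc1cc(O)c(C(=O)/C=C/c2ccc(Br)cc2)c(-c2ccccc2)c1C(=O)/C=C/c1ccc(Br)cc1`, gives 10000 nM.

All three compounds share one core and differ only in where bromine sits on their outer rings. Going from compound 1 to compound 2, the change is bromo in place of hydrogen on an aromatic carbon, and the result is no change at the digits printed from compound 1 to compound 2 (within the scatter). Compound 3 differs from compound 1 in more than one place, so the difference between the two cores is not broken down here; what the two values show is that compound 1 and compound 3 sit level in this assay.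

Compound 4, `Cc1cc(O)c(C(=O)/C=C/c2ccc(Br)cc2)c(-c2ccc(Br)cc2)c1C(=O)/C=C/c1ccc(Br)cc1`, is not yet measured. It differs from compound 3 by bromo in place of hydrogen on an aromatic carbon, the same change that was made from compound 1 to compound 2, at a place described in the same words. Because that earlier change gave no change at the digits printed from compound 1 to compound 2 (within the scatter), the step from compound 3 to compound 4 is expected to be no change at the digits printed from compound 3 to compound 4 (within the scatter). On that basis compound 4 is estimated at 10000 nM, with a range from 5000 nM to 20000 nM.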

Compound 4, half-maximal inhibitory concentration: 15000 nM
For compound 4 the middle estimate is 1.5-fold (0.18 log units) below the measured one; low and high end bracket the measured number.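

In this assay, the change from phenyl to 4-bromophenyl gives a 1.5-fold higher number from compound 3 to compound 4 (0.18 log units; within the scatter), and set beside the same change on the other core, the two steps agree: the same change on two cores in this assay, no change at the digits printed (within the scatter) from compound 1 to compound 2 and a 1.5-fold higher number (0.18 log units; within the scatter) from compound 3 to compound 4, 1.5-fold (0.18 log units) apart, within the scatter of two such steps So in this small set, the change carries from the core of compound 1 to the core of compound 3 with no difference that can be told from ordinary measurement noise. Within the data shown here, this rests on only two pairs of compounds, and neither step stands out from the scatter, so the agreement is between two steps that show no clear effect, not between two clear effects, and it does not show how the change would behave on any other core.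

The compounds shown leave open whether a different group at the same place, such as an amine, a carboxylic acid or a methoxy group, would move the number on either core. On these data alone, only hydrogen and bromo appear there, so what the outer rings can contribute in this assay remains unknown.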